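Swapping the Aryl Group on an Arylidene Oxindole

The source may report more compounds than this note shows. Statements on the series, on what has been measured and on what is new or still open speak of the compounds shown alone.

Measured compounds:
- compound 1 `COc1ccc(/C=C2\C(=O)N(c3c(Cl)cccc3Cl)c3ccccc32)cc1` — "not determined" (no result reported)
- compound 2 `O=C1/C(=C\c2cccc(Br)c2)c2ccccc2N1c1c(Cl)cccc1Cl` — 7 ug/mL

Two compounds share the same core here. For compound 1 the entry in a functional assay on MOLT-4 cells (Homo sapiens) for cytotoxicity, read by MTT assay, with a stated time of 72 h (on this read-out lower numbers stand for an effect already at smaller amounts and higher numbers for an effect only at larger amounts of compound), reads "not determined" (no result reported), so nothing can be said about it beyond its structure. Going by the values given here, compound 2 is therefore the only compound with a number: in this assay compound 2 gives 7 ug/mL, and it stands alone, with nothing to compare against.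

Compound 3 `O=C1/C(=C\c2ccccc2[N+](=O)[O-])c2ccccc2N1c1c(Cl)cccc1Cl` has not been measured. It differs from compound 2 in one place: 2-nitrophenyl in place of 3-bromophenyl on a double-bonded chain carbon bound to a double-bonded ring carbon. Among the compounds with values here, no pair of measured compounds shows what such a swap does, so the size of the step cannot be read from the data. The expectation is a small step in this assay, toward an effect only at slightly larger amounts, but not clearly beyond the usual scatter; the estimated step from compound 2 to compound 3 is a 1.4-fold higher number from compound 2 to compound 3 (0.15 log units; within the scatter). Compound 3 is expected to give about 10 ug/mL in this assay, with a likely range from 3 ug/mL to 30 ug/mL.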

Compound 3, concentration for half-maximal effect: 6 ug/mL
Estimate against measurement, compound 3: 1.7-fold (0.22 log units) above; low and high end bracket the measured number.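

In this assay, going by these compounds alone, 2-nitrophenyl in place of 3-bromophenyl on a double-bonded chain carbon bound to a double-bonded ring carbon gives a 1.2-fold lower number from compound 2 to compound 3 (0.07 log units; within the scatter) and so provides the first comparison at this position. Although the aryl ring exchanges its bromine for a nitro group, which brings hydrogen-bond acceptors to a group that had none, the two numbers cannot be told apart, so this one change leaves the read-out where it was. Nothing shown bears on why that is so.

The step to compound 1 cannot be read, as its entry holds no number, so the two compounds with numbers are the only view of this position and one pair sets no trend. Going by these compounds, it remains open whether an amine or a carboxylic acid on the aryl ring, or a longer chain in place of that ring, would also leave the number unchanged or would move it beyond the usual scatter.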